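Replacing the 3,5-dichlorophenyl in compound 2

The source may report more compounds than this note shows. Statements on the series, on what has been measured and on what is new or still open speak of the compounds shown alone.

Three compounds of the series have a reading so far. In an ADME assay on MRC5 cells (Homo sapiens) for inhibition, with a stated time of 72 h (on this read-out lower numbers stand for an effect already at smaller amounts and higher numbers for an effect only at larger amounts of compound), compound 2 `CO[C@H]1CC[C@H](NC(=O)c2n[nH]cc2NC(=O)c2cc(Cl)cc(Cl)c2)CC1` gives 13000 nM, the lower of the two numbers available. Compound 1 `COc1cccc(OC)c1C(=O)Nc1c[nH]nc1C(=O)NC1CCN(Cc2ccccc2)C1` gives 38000 nM, a gap from compound 2 that lies beyond the scatter. Compound 3 `CCCCCNC(=O)c1n[nH]cc1NC(=O)c1c(OC)cccc1OC` gives > 50000 nM, which is a limit of the assay and not a number; (the limit of > 50000 nM in this assay, at which 1 of the 3 values shown sits).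

Compound 4 `CO[C@H]1CC[C@H](NC(=O)c2n[nH]cc2NC(=O)c2cc3ccccn3n2)CC1` differs from compound 2 on a carbonyl carbon: a group of 9 heavy atoms (7 carbon, 2 nitrogen; one five-membered aromatic ring with 2 hetero atoms, one six-membered aromatic ring with 1 hetero atom) in place of a group of 8 heavy atoms (6 carbon, 2 chlorine; one six-membered aromatic ring of carbon only), on a carbonyl carbon. Within the data shown here, compound 2, at 13000 nM, is the only measured compound with the 3,5-dichlorophenyl, and no measured pair isolates this group, so the expectation is loosely founded. A moderate move towards a higher number is expected in this assay, with the estimated step of a 2.5-fold higher number from compound 2 to compound 4 (0.39 log units; beyond the scatter), since the other two compounds both read higher than compound 2. A reading reported only as a limit would not be surprising. For compound 4, the estimated value is 32000 nM, with an expected range of 14000 nM to 50000 nM.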

Compound 4, half-maximal effective concentration: 1000 nM
For compound 4 the middle estimate is 32-fold (1.51 log units) above the measured one; the measured number lies below the stated range.
By their numbers in this assay, from the lowest: compound 4; then compound 2; then compound 1. At a limit, above all of these: compound 3.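

Among these compounds, the carbonyl carbon is the first place where a single change can be read: in this assay, the step is a 13-fold lower number from compound 2 to compound 4 (1.11 log units; beyond the scatter), so the group held there alone can shift the reading by a large margin. Compound 2 therefore does not mark a floor for this assay, and the 3,5-dichlorophenyl is not needed for a low number, as compound 4 carries neither chlorine nor a carbon-only ring at this place. Nothing shown here gives a cause for this step.

Among the compounds shown here, still open is which part of the incoming group carries the step, since only one pair isolates this place. Going by these compounds, how an unsubstituted phenyl, a pyridine or a carboxylic acid on a phenyl would read at the same carbonyl carbon also remains unknown.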